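This account rests on a few compounds, and the source may have more. Where it says the series, first, only, none or still open, it means among the compounds named here.

Measured compounds:
compound 1, `CCCCNC(=O)NS(=O)(=O)c1ccc(-n2nc(-c3ccc(OC)cc3)ccc2=O)cc1`, 43.7%
compound 2, `Cc1ccc(-c2ccc(=O)n(-c3ccc(S(=O)(=O)NC(=O)NCc4ccccc4)cc3)n2)cc1`, 64.9%

Of the compounds shown here, two have been measured in a functional assay on the whole organism (blood, strain Wistar albino) for inhibition, with Rattus norvegicus as the target, read by colorimetric assay, with stated times of 15 min and 90 min, at a dose of 20 mg/kg by the oral route; on this read-out lower numbers stand for less inhibition and higher numbers for more inhibition at the one dose given (going by the name of the read-out). Compound 1 gives 43.7%, and compound 2 gives 64.9%. Of these two numbers, compound 1 stands lowest; its nearest neighbour, compound 2, lies higher by a margin beyond the scatter. Among the measured compounds shown here, no step between measured compounds that differ in one place is available, and compound 2 differs from compound 1 in more than one place, so the two values show only that compound 2 inhibits more than compound 1 at the dose given.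

Compound 3, `CCCCNC(=O)NS(=O)(=O)c1ccc(-n2nc(-c3ccc(Cl)cc3)ccc2=O)cc1`, is not yet measured. It differs from compound 1 by chloro in place of methoxy on an aromatic carbon. For the measured compounds named here, no measured pair carries this change alone, so no measured step bears on it directly. In this assay no step beyond the scatter is expected from this change, in either direction. The estimate for compound 3 is 46%, with a range from 30% to 62%. The step of a number 2.3 percentage points higher from compound 1 to compound 3 (within the scatter) that this estimate implies is expected to stay within the scatter of repeated measurements.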

Compound 3, a percentage reported as inhibition, in the whole organism at one dose (the size of the read-out at that dose, not a potency): 66%
For compound 3 the middle estimate is 20 percentage points below the measured one, outside the stated range (above it).
By their numbers in this assay, from the lowest: compound 1; then compounds 2 and 3 (each within the scatter of the next).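

In this assay, among the compounds shown here, the change from 4-methoxyphenyl to 4-chlorophenyl gives the first step that can be read at a single place: a number 22.3 percentage points higher from compound 1 to compound 3 (beyond the scatter). The position on the aromatic carbon para to a large group is therefore not indifferent to what it carries, and with the rest of compound 1 unchanged, the read-out at this one dose responds to this exchange alone. The exchange replaces a group of 2 heavy atoms and 1 hydrogen-bond acceptor with one of 1 heavy atom and 0 hydrogen-bond acceptors, but this single pair does not separate those differences, and no measurement at hand accounts for the step.

The compounds shown leave open whether the step follows from the arrival of chloro or the departure of methoxy, a question that fluoro, bromo or trifluoromethyl at the same place would bear on. They also leave open whether the same exchange gives a step of similar size when the rest of the molecule differs, and how the step would look at any other dose.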